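This account rests on a few compounds, and the source may have more. Where it says the series, first, only, none or still open, it means among the compounds named here.

The series is measured in a functional assay on T47D cells (Homo sapiens) for antiproliferative activity, read by MTT assay, with a stated time of 72 h; on this read-out lower numbers stand for stronger inhibition and higher numbers for weaker inhibition. Compound 1 `COc1cc(-c2nccn2CC(C)C)cc(OC)c1OC` carries an isobutyl on a ring nitrogen of the shared core; in this assay compound 1 reaches only the limit > 100000 nM, so its standing on the numbers shown is a limit and not a number. Compound 2 `COc1cc(-c2nccn2S(=O)(=O)c2ccccc2)cc(OC)c1OC` likewise gives only the limit > 100000 nM in this assay. Compound 3 `COc1cc(-c2nccn2S(=O)(=O)c2ccc(C)cc2)cc(OC)c1OC` also stops at the limit > 100000 nM in this assay. Going by the values given here, the single step between measured compounds, a step that the two limits leave unreadable from compound 2 to compound 3, cannot be read in size, since every value shown sits at the same limit (the limit of > 100000 nM in this assay, at which 3 of the 3 values shown sit).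

Compound 4 `COc1ccc(-n2ccnc2-c2cc(OC)c(OC)c(OC)c2)cc1` differs from compound 1 by 4-methoxyphenyl in place of isobutyl on an aromatic nitrogen. Among the compounds with values here, no measured step touches this change, and the three limits give no direction for it. The step from compound 1 to compound 4 is therefore estimated rather than read: the expected step is an at least 200-fold lower number from compound 1 to compound 4 (2.30 log units; beyond the scatter). Compound 4 is estimated to give about 500 nM in this assay, within a broad range from 20 nM to 50000 nM.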

Compound 4, half-maximal inhibitory concentration: 1400 nM
The estimate for compound 4 lay 2.8-fold (0.45 log units) below the measured number; the measured number falls inside the stated range.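

With 4-methoxyphenyl in place of isobutyl on the aromatic nitrogen, the series shows an at least 71-fold lower number from compound 1 to compound 4 (1.85 log units; beyond the scatter), so this position can carry a change that moves the read-out off the limit. Compound 2 and compound 3 also hold a six-membered aromatic ring of carbon only on that nitrogen, though joined through a sulfonyl, and both stay at a limit, so such a ring alone does not bring a number. Compound 4, at 1400 nM, is the only compound here with a number rather than a limit: the limit of > 100000 nM in this assay, at which 3 of the 4 values shown sit.

From the compounds shown here alone, what a plain phenyl would give on this nitrogen, and so whether the ring or its methoxy carries the step, stays open. Also open, going by these compounds, is how a benzyl, or a hydroxyl or an amine in place of the methoxy, would read.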